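From isopropyl to benzyl: expected step to compound 4

The compounds below may be only part of what the source reports. "The series", "measured", "known", "first", "only" and "open" are said of these compounds alone.

Compound 3 `CC(C)Nc1nc(NC(C)C)c2ccccc2n1` reads > 30000 nM in an ADME assay on J774.A1 cells (Mus musculus) for inhibition, read by MTT assay, with a stated time of 72 h (a higher number here means that more compound is needed for the effect, a lower number that less compound is needed), and this is a limit of the assay, not a number. Compound 4 `CC(C)Nc1nc(NCc2ccccc2)nc2ccccc12` carries benzyl in place of isopropyl on a nitrogen on an aromatic ring. In this assay compound 1 `COc1ccc(CNc2nc(NCc3ccccc3)nc3ccccc23)cc1` gives 5200 nM and compound 2 `Clc1ccc(CNc2nc(NCc3ccccc3)nc3ccccc23)cc1` gives 4600 nM as true numbers, and both hold a benzyl on such a nitrogen. Among the measured compounds shown here, the only measured step is a 1.1-fold lower number from compound 1 to compound 2 (0.05 log units; within the scatter) for chloro in place of methoxy on an aromatic carbon. It lies within the scatter and does not touch the change at hand, so it bears on it only weakly. A lower number is therefore expected for compound 4, resting on compound 1 at 5200 nM and compound 2 at 4600 nM as the closest measured structures. One isopropyl remains in compound 4, so a value somewhat short of those two is expected. The estimated step is an at least 2.5-fold lower number from compound 3 to compound 4 (0.39 log units; beyond the scatter) in this assay and stays loose, since compound 3 has no number. The estimated value for compound 4 is 12000 nM (expected range 5000 nM to 30000 nM).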

Compound 4, half-maximal effective concentration: 7200 nM
Estimate against measurement, compound 4: 1.7-fold (0.22 log units) above, and the stated range covers the measured number.
By their numbers in this assay, from the lowest: compounds 2, 1 and 4 (each within the scatter of the next). At a limit, above all of these: compound 3.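

In this assay, among the compounds shown here, benzyl in place of isopropyl on a nitrogen on an aromatic ring gives an at least 4.1-fold lower number from compound 3 to compound 4 (0.61 log units; beyond the scatter), the first step that lies beyond the scatter. Compound 3 stands at a limit of the assay, not at a number, so this step has only a bound: the limit of > 30000 nM in this assay, at which 1 of the 4 values shown sits. The further change adds nothing that can be told apart, since isopropyl in place of 4-chlorobenzyl gives a 1.6-fold higher number from compound 2 to compound 4 (0.19 log units; within the scatter) and isopropyl in place of 4-methoxybenzyl gives a 1.4-fold higher number from compound 1 to compound 4 (0.14 log units; within the scatter), both within the scatter.

On these data alone, whether the step depends on the aromatic ring of benzyl or only on a larger group stays open, and cyclohexylmethyl or a longer chain such as n-butyl on that nitrogen would separate the two. As far as these compounds go, how a carboxylic acid or a free amine at the end of such a chain would read also stays open.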